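Adding a chloro to the phenyl ring of compound 3

The compounds below may be only part of what the source reports. "The series", "measured", "known", "first", "only" and "open" are said of these compounds alone.

In a functional assay on DU-145 cells (Homo sapiens) for cytotoxicity, read by trypan blue exclusion, with a stated time of 96 h (a lower number here means a stronger inhibitor, a higher number a weaker inhibitor), compound 1 `COc1cc(OC)c(/C=C/S(=O)(=O)Cc2ccc(OC)c([N+](=O)[O-])c2)c(OC)c1` gives 2500 nM and compound 2 `COC(=O)CCNc1cc(CS(=O)(=O)/C=C/c2c(OC)cc(OC)cc2OC)ccc1OC` gives 1500 nM, and the step between them, a 1.7-fold lower number from compound 1 to compound 2 (0.22 log units; within the scatter), is small. Compound 3 `COc1cc(OC)c(/C=C/S(=O)(=O)Cc2ccc(OC)c(NC(C(=O)O)c3ccccc3)c2)c(OC)c1` gives 20 nM, the lowest number of the three. The steps leading to it are large: a 130-fold lower number from compound 1 to compound 3 (2.10 log units; beyond the scatter) and a 75-fold lower number from compound 2 to compound 3 (1.88 log units; beyond the scatter).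

Compound 4 `COc1cc(OC)c(/C=C/S(=O)(=O)Cc2ccc(OC)c(NC(C(=O)O)c3ccc(Cl)cc3)c2)c(OC)c1` differs from compound 3 by a single change, chloro in place of hydrogen on an aromatic carbon, para to a large group: chloro in place of hydrogen on an aromatic carbon. The two large steps show how much the number moved when the carboxy(phenyl)methyl group was introduced, but neither involves a substituent on its phenyl ring. Among the compounds with values here, no measured pair tests this change directly, so the evidence for its size is thin. In this assay, no step beyond the scatter is therefore expected, though the uncertainty is wide. The expected step is a 1.1-fold lower number from compound 3 to compound 4 (0.05 log units; within the scatter). For compound 4 the estimated value is 18 nM, with an expected range from 5 nM to 60 nM.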

Compound 4, half-maximal inhibitory concentration: 400 nM
Compound 4: the middle estimate sits 22-fold (1.35 log units) below what was measured; measured number above the stated range.
By their numbers in this assay, from the lowest: compound 3; then compound 4; then compounds 2 and 1 (each within the scatter of the next).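

In this assay the phenyl ring of the carboxy(phenyl)methyl group proves far from indifferent to substitution: chloro in place of hydrogen, para to a large group, gives a 20-fold higher number from compound 3 to compound 4 (1.30 log units; beyond the scatter) and gives back much of what that group had gained. The gain is not lost entirely, since the carboxy(4-chlorophenyl)methyl group still gives a 3.8-fold lower number from compound 2 to compound 4 (0.57 log units; beyond the scatter) and the (carboxy(4-chlorophenyl)methyl)amino group still gives a 6.3-fold lower number from compound 1 to compound 4 (0.80 log units; beyond the scatter) in place of nitro. Nothing available on these compounds accounts for the size of the chloro step.

The compounds shown leave open whether this loss belongs to chloro itself or would also follow fluoro, methyl or methoxy at the same place. They also leave open how chloro would fare on another carbon of this ring.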